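The source may report more compounds than this note shows. Statements on the series, on what has been measured and on what is new or still open speak of the compounds shown alone.

Compound 1 `COc1ncc(-c2ccc3ncnc(Nc4cnn(CC(=O)O)c4)c3c2)cc1NS(=O)(=O)c1ccc(F)cc1F`: 700 nM
Compound 2 `COc1ncc(-c2ccc3ncnc(Nc4ccc(OCCO)nc4)c3c2)cc1NS(C)(=O)=O`: 3080 nM

In a functional assay on MCF7 cells (Homo sapiens) for antiproliferative activity, read by sulforhodamine B assay, with a stated time of 72 h (a higher number here means a weaker inhibitor, a lower number a stronger inhibitor), compound 2 gives the highest of the two numbers, and compound 1 gives a number beyond the scatter below it. Compound 3 `COc1ncc(-c2ccc3ncnc(Nc4ccc(OCCO)nc4)c3c2)cc1NS(=O)(=O)c1ccc(F)cc1F` is not yet measured. It differs from compound 2 by 2,4-difluorophenyl in place of methyl on a sulfonyl sulfur. Among the measured compounds shown here, the two measured compounds differ in more than this one place, so no single step is known for it. A move to a lower number is expected, of a size about a 3.1-fold lower number from compound 2 to compound 3 (0.49 log units; beyond the scatter). Compound 3 is expected to give 1000 nM, somewhere between 300 nM and 3000 nM.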

Compound 3, half-maximal inhibitory concentration: 4300 nM
Compound 3: the middle estimate sits 4.3-fold (0.63 log units) below what was measured, outside the stated range (above it).
By their numbers in this assay, from the lowest: compound 1; then compounds 2 and 3 (each within the scatter of the next).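

In this assay, placing 2,4-difluorophenyl instead of methyl on the sulfonyl sulfur gives a 1.4-fold higher number from compound 2 to compound 3 (0.14 log units; within the scatter) and so makes no readable difference alongside the 6-(2-hydroxyethoxy)pyridin-3-yl group. With that sulfonyl group held fixed, a 6.1-fold higher number from compound 1 to compound 3 (0.79 log units; beyond the scatter) comes with 6-(2-hydroxyethoxy)pyridin-3-yl in place of 1-(carboxymethyl)-1H-pyrazol-4-yl, so the readable change lies at this other place. Nothing shown gives a reason for either result. Still open, as far as these compounds go, is whether methyl on the sulfonyl sulfur would also make no readable difference alongside 1-(carboxymethyl)-1H-pyrazol-4-yl, and how an amine in place of the hydroxyl of the 2-hydroxyethoxy chain would read.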